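Amine-side variation in the prenylated coumarin amide series

This account rests on a few compounds, and the source may have more. Where it says the series, first, only, none or still open, it means among the compounds named here.

Three compounds with the shared core of compound 1 `CC(C)=CCc1cc(C(=O)Nc2cc3ccc(OCCC4CCCCN4)c(C)c3oc2=O)ccc1O` have been measured in a functional assay on SK-BR-3 cells (Homo sapiens) for antiproliferative activity; on this read-out lower numbers stand for stronger inhibition and higher numbers for weaker inhibition. Compound 1 gives 640 nM. Compound 2 `CC(C)=CCc1cc(C(=O)Nc2cc3ccc(OCC4CCCNC4)c(C)c3oc2=O)ccc1O` gives 600 nM, and compound 3 `CC(C)=CCc1cc(C(=O)Nc2cc3ccc(OCCCN(C)C(C)C)c(C)c3oc2=O)ccc1O` gives 570 nM. The steps between them are small: a 1.1-fold lower number from compound 1 to compound 2 (0.03 log units; within the scatter), a 1.1-fold lower number from compound 1 to compound 3 (0.05 log units; within the scatter) and a 1.1-fold lower number from compound 2 to compound 3 (0.02 log units; within the scatter). Compound 3 therefore stands together with compound 2 and compound 1; nothing separates the three beyond the scatter.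

Compound 4 `CC(C)=CCc1cc(C(=O)Nc2cc3ccc(OCCCN(C)c4ccccc4)c(C)c3oc2=O)ccc1O` differs from compound 3 at the amine nitrogen: phenyl in place of isopropyl on an amine nitrogen. Among the measured compounds shown here, no measured step varies this substituent, so the three steps above bear on it only indirectly, showing that exchanges around the amine have so far stayed within the scatter. On that basis a step of no more than the scatter is expected in this assay, with no direction assigned, which is what no change at the digits printed from compound 3 to compound 4 (within the scatter) means. Compound 4 is estimated at 570 nM, with a range from 250 nM to 1300 nM.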

Compound 4, half-maximal inhibitory concentration: > 50000 nM
Compound 4 ended at the assay's limit; the forecaster's own chance of this, stated with the estimate: 3%; at least 87-fold (1.94 log units) between middle value and limit.
By their numbers in this assay, from the lowest: compounds 3, 2 and 1 (each within the scatter of the next). At a limit, above all of these: compound 4.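

In this assay, the amine nitrogen is the one place in the series where an exchange moves the read-out beyond the scatter, with phenyl in place of isopropyl giving an at least 87-fold higher number from compound 3 to compound 4 (1.94 log units; beyond the scatter). The comparisons with the ring amines point the same way, an at least 83-fold higher number from compound 2 to compound 4 (1.92 log units; beyond the scatter) and an at least 78-fold higher number from compound 1 to compound 4 (1.89 log units; beyond the scatter), so the piperidin-2-yl, piperidin-3-yl and isopropyl(methyl)amino groups sit together on one side of this gap and methyl(phenyl)amino on the other. The value of compound 4 is a limit of the assay, not a number: the limit of > 50000 nM in this assay, at which 1 of the 4 values shown sits.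

Still open, as far as these compounds go, is whether the loss follows the aromatic ring itself or the larger group on this nitrogen; a cyclohexyl or benzyl group in the same place would separate the two. Also open, from the compounds shown here alone, is whether a pyridyl ring on this nitrogen reads like phenyl.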